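A Methoxy Swap on the Benzyl Ring

The source may hold more compounds than are shown below. What is called first, only, known or untested is meant among the compounds shown, and "the series" means these compounds.

In a functional assay on MDA-MB-231 cells (Homo sapiens) for inhibition, read by CCK-8 assay, with a stated time of 48 h (on this read-out lower numbers stand for stronger inhibition of growth and higher numbers for weaker inhibition of growth), compound 1 `CN1CCN(c2ccc(Nc3ncc(Cl)c(Nc4ccccc4)n3)nc2)CC1` gives 37400 nM and compound 2 `CN1CCN(c2ccc(Nc3ncc(Cl)c(NCc4ccccc4)n3)nc2)CC1` gives 24800 nM, while compound 3 `Cc1ccc(CNc2nc(Nc3ccc(N4CCN(C)CC4)cn3)ncc2Cl)cc1` gives 18600 nM and so stands within the scatter of both others. Compound 4 `COc1ccccc1CNc1nc(Nc2ccc(N3CCN(C)CC3)cn2)ncc1Cl` differs from compound 3 in one group (2-methoxyphenyl in place of 4-methylphenyl on a saturated chain carbon bound to a nitrogen on an aromatic ring), with 2-methoxyphenyl in place of 4-methylphenyl. The measured steps that bear on this are small: adding the methyl (a 1.3-fold lower number from compound 2 to compound 3 (0.12 log units; within the scatter)) and the two changes away from phenyl (a 1.5-fold lower number from compound 1 to compound 2 (0.18 log units; within the scatter) and a 2.0-fold lower number from compound 1 to compound 3 (0.30 log units; within the scatter)) all stay within the scatter. Within the data shown here, no measured compound carries 2-methoxyphenyl, so no step beyond the scatter is expected (a 1.1-fold higher number from compound 3 to compound 4 (0.03 log units; within the scatter)). Compound 4 is estimated at 20000 nM (expected range 9000 nM to 42000 nM).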

Compound 4, concentration for 50% growth inhibition: 29300 nM
Compound 4: the middle estimate sits 1.5-fold (0.17 log units) below what was measured; low and high end bracket the measured number.
By their numbers in this assay, from the lowest: compounds 3, 2, 4 and 1 (each within the scatter of the next).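

Even with a methoxy group, which brings an oxygen and a hydrogen-bond acceptor onto the benzyl ring, this assay barely responds: 2-methoxyphenyl in place of 4-methylphenyl gives a 1.6-fold higher number from compound 3 to compound 4 (0.20 log units; within the scatter). Methoxy in place of hydrogen gives a 1.2-fold higher number from compound 2 to compound 4 (0.07 log units; within the scatter), and 2-methoxybenzyl in place of phenyl gives a 1.3-fold lower number from compound 1 to compound 4 (0.11 log units; within the scatter), so this position has yet to show a step beyond the scatter. No measurement offered here explains these small steps. As far as these compounds go, whether an amine or a carboxylic acid on this ring, or a longer chain before it, would give such a step remains open.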